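Amino for methyl on a shared propargyloxy-bearing core

The source may hold more compounds than are shown below. What is called first, only, known or untested is meant among the compounds shown, and "the series" means these compounds.

Two compounds of this series have a value in an assay on BTI-TN-5B1-4 cells for inhibition of Amine oxidase [flavin-containing] A (Homo sapiens), read by fluorescence and Amplex Red, using microsomes, with a stated time of 30 min; a lower number here means a stronger inhibitor, a higher number a weaker inhibitor. Compound 1 `C#CCOc1ccc(-c2cc(-c3ccccc3OCC#C)nc(N)n2)cc1` gives 28600 nM in this assay. Compound 2 `C#CCOc1ccc(-c2cc(-c3ccc(OCC#C)cc3)nc(C)n2)cc1` gives 34200 nM in this assay, the higher of the two numbers, though compound 1 sits close enough that the gap between them lies within the scatter, so neither can be called the weaker inhibitor on these data.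

Compound 3 `C#CCOc1ccc(-c2cc(-c3ccc(OCC#C)cc3)nc(N)n2)cc1` is the next member, not yet measured. It differs from compound 2 in one place: amino in place of methyl on an aromatic carbon. Going by the values given here, no directly comparable pair has both values known, so there is no measured step to lean on. Compound 1, which also carries the amino group, gives a number no different from compound 2 beyond the scatter, which gives no sign that the amino group moves potency far in either direction. Compound 3 is therefore expected to land close to compound 2, with a step of a 1.3-fold lower number from compound 2 to compound 3 (0.12 log units; within the scatter) that stays within the scatter. Compound 3 is estimated at 26000 nM, with a range from 10000 nM to 65000 nM.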

Compound 3, half-maximal inhibitory concentration: 32100 nM
The estimate for compound 3 lay 1.2-fold (0.09 log units) below the measured number; the range from low to high includes it.
By their numbers in this assay, from the lowest: compounds 1, 3 and 2 (each within the scatter of the next).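

In this assay, the exchange of methyl for amino on the aromatic carbon between two ring nitrogen atoms gives a 1.1-fold lower number from compound 2 to compound 3 (0.03 log units; within the scatter). Going by these compounds alone, this is the first direct reading of the change, since compound 1 had offered only indirect support, and it shows that on this core the two groups cannot be told apart in this assay. Amino brings a hydrogen-bond donor and a hydrogen-bond acceptor that methyl does not carry, yet this difference in the counts goes with no change in the number beyond the scatter, and nothing available explains that outcome.

The compounds shown leave open whether this position tolerates any substituent equally or whether methyl and amino merely happen to match, a question that a hydroxyl, a dimethylamino group or a longer chain such as propyl at the same carbon could address. They also leave open whether the exchange of methyl for amino would read the same way with the propargyloxy groups placed differently, as they are in compound 1, or replaced by a methoxy group.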